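Compound 3 to compound 4: 2-bromophenyl enters

The source may report more compounds than this note shows. Statements on the series, on what has been measured and on what is new or still open speak of the compounds shown alone.

In a functional assay on MCF7 cells (Homo sapiens) for antiproliferative activity, read by MTT assay, with a stated time of 48 h (on this read-out higher numbers stand for weaker inhibition and lower numbers for stronger inhibition), compound 1 `N=C(N)N/N=C(/C=C/c1ccc(F)cc1)c1ccccc1` gives 2500 nM while compound 2 `N=C(N)N/N=C(/C=C/c1ccc(Cl)cc1)c1ccccc1` gives 700 nM and compound 3 `Cc1ccc(/C=C/C(=N/NC(=N)N)c2ccccc2)cc1` gives 16000 nM as the highest number of the three. Compound 4 `N=C(N)N/N=C(/C=C/c1ccccc1Br)c1ccccc1` differs from compound 3 by 2-bromophenyl in place of 4-methylphenyl (2-bromophenyl in place of 4-methylphenyl on a double-bonded chain carbon bound to a double-bonded chain carbon). The nearest precedents are the methyl steps, with a 6.4-fold higher number from compound 1 to compound 3 (0.81 log units; beyond the scatter) being modest and a 23-fold higher number from compound 2 to compound 3 (1.36 log units; beyond the scatter) being large. The halogens themselves are separated by a 3.6-fold lower number from compound 1 to compound 2 (0.55 log units; beyond the scatter) as a modest step. Within the data shown here, no measured compound carries bromine or the 2-bromophenyl group, so this transfer is uncertain. A modest to large fall is expected, with the estimated change being an 8.9-fold lower number from compound 3 to compound 4 (0.95 log units; beyond the scatter) in this series. Compound 4 is expected at 1800 nM (estimated range 450 nM to 7000 nM).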

Compound 4, half-maximal inhibitory concentration: 4200 nM
Estimate against measurement, compound 4: 2.3-fold (0.37 log units) below, within the range that was stated.
By their numbers in this assay, from the lowest: compound 2; then compounds 1 and 4 (each within the scatter of the next); then compound 3.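

2-bromophenyl in this place in this assay keeps the number under that of the 4-methylphenyl compound (a 3.8-fold lower number from compound 3 to compound 4 (0.58 log units; beyond the scatter)) but not down at the 4-chlorophenyl level (a 6.0-fold higher number from compound 2 to compound 4 (0.78 log units; beyond the scatter)). Against 4-fluorophenyl there is no separation (a 1.7-fold higher number from compound 1 to compound 4 (0.23 log units; within the scatter)), so all three halogen-bearing compounds now lie under compound 3, while compound 2 stays apart from both compound 1 and compound 4. Halogen identity and ring placement change together in compound 4, and 4-bromophenyl or 2-chlorophenyl would be needed to part them. Going by these compounds, an amine or a methoxy group here remains untested in these compounds. No supporting data bear on the reason for these steps.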